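Halogenated aryl ethers on a shared core

The compounds below may be only part of what the source reports. "The series", "measured", "known", "first", "only" and "open" are said of these compounds alone.

Among the measured compounds shown here, compound 1 `NC1=NC2(CCSCC2)N(OCCCOc2cccc(Cl)c2Cl)C(N)=N1` is the only member of the series with a number so far. In an assay on isolated protein for inhibition of Dihydrofolate reductase (Homo sapiens), read by spectrophotometry, using NADPH, with stated times of 5 s and 6 min, tested at 50 uM (on this read-out higher numbers stand for a stronger effect at the one concentration tested and lower numbers for a weaker effect), compound 1 gives 89.8%. Compound 2 `COc1ccc(OCCCON2C(N)=NC(N)=NC23CCOCC3)cc1` carries a different aryl ether and a different saturated ring on the shared core; in this assay compound 2 gives "not determined" (no result reported), so no number stands beside it. Compound 3 `NC1=NC2(CCSCC2)N(OCCCOc2ccccc2Br)C(N)=N1` keeps the core and the chain of compound 1 and differs only at the aryl ether: 2-bromophenyl in place of 2,3-dichlorophenyl on an oxygen on a saturated carbon. For the measured compounds named here, no step between two measured compounds is available, so the size of this change in this assay can only be estimated. Since compound 1 already gives 89.8%, there is little room upward, and the step is expected to be small, downward if anything, most likely within the scatter. The step expected from compound 1 to compound 3 is a number 7.8 percentage points lower from compound 1 to compound 3 (within the scatter). Compound 3 is therefore estimated at 82%, with a range from 65% to 95%.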

Compound 3, a percentage reported as inhibition, at one concentration (the size of the read-out at that concentration, not a potency): 89.6%
Estimate against measurement, compound 3: 7.6 percentage points below; low and high end bracket the measured number.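

In this assay, among the compounds shown here, the swap of 2-bromophenyl in place of 2,3-dichlorophenyl on an oxygen on a saturated carbon gives a number 0.2 percentage points lower from compound 1 to compound 3 (within the scatter) and so provides the first readable step: at this position, a single bromine and two chlorines cannot be told apart on this read-out. The read-out comes from one concentration, so any difference between the two aryl ethers in the strength of their effect at other concentrations may remain out of view. No measured evidence bears on the reason for this result.

On these data alone, whether an amine or a carboxylic acid on the phenyl ring would hold the read-out remains open, as does the effect of a longer chain in place of the present one. Compound 2 has no reported number, so the saturated ring on the shared core cannot yet be judged.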